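Iodo to Nitro Exchange in an Antiproliferative Series

A few compounds are considered here, and "the series" means these few. Any claim that something is new, unique, unknown or untested is made for them only; others in the source may bear on it.

Of the compounds shown here, three of a shared core have been measured in a functional assay on A549 cells (Homo sapiens) for antiproliferative activity, read by MTT assay, with a stated time of 48 h; a lower number here means a stronger inhibitor, a higher number a weaker inhibitor. Compound 1 `COc1ccc2nc(NC(c3cn(-c4ccccc4)nc3-c3cccc([N+](=O)[O-])c3)c3c(O)ccc4ccccc34)sc2c1` gives 52200 nM. Compound 2 `COc1ccc2nc(NC(c3cn(-c4ccccc4)nc3-c3cccc(I)c3)c3c(O)ccc4ccccc34)sc2c1` gives 39300 nM. Compound 3 `Oc1ccc2ccccc2c1C(Nc1nc2ccc(Cl)cc2s1)c1cn(-c2ccccc2)nc1-c1ccc(I)cc1` gives 29000 nM; the difference between the core of compound 3 and the core of compound 2 is not broken down here, and the two values lie within the scatter of each other. Between compound 2 and compound 1 the change is nitro in place of iodo on an aromatic carbon, and it made a 1.3-fold higher number from compound 2 to compound 1 (0.12 log units; within the scatter).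

Compound 4 `O=[N+]([O-])c1ccc(-c2nn(-c3ccccc3)cc2C(Nc2nc3ccc(Cl)cc3s2)c2c(O)ccc3ccccc23)cc1` has not yet been measured. It differs from compound 3 by nitro in place of iodo on an aromatic carbon. Among the measured compounds shown here, this is the same kind of change as the one from compound 2 to compound 1, but not the same: there the group sits meta to a large group, here it sits para to a large group. A step of a 1.3-fold higher number from compound 3 to compound 4 (0.12 log units; within the scatter) is expected, because the earlier exchange gave a 1.3-fold higher number from compound 2 to compound 1 (0.12 log units; within the scatter), a step within the scatter. Compound 4 is therefore expected to give about 38000 nM in this assay, most likely between 15000 nM and 95000 nM.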

Compound 4, half-maximal inhibitory concentration: 57200 nM
For compound 4 the middle estimate is 1.5-fold (0.18 log units) below the measured one; the range from low to high includes it.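

In this assay, nitro in place of iodo, here 4-iodophenyl to 4-nitrophenyl, gives a 2.0-fold higher number from compound 3 to compound 4 (0.29 log units; within the scatter), so on this second core the exchange again stays inside the scatter. Set side by side, the two steps cannot be told apart, and the exchange carries from one core to the other with no detectable difference: the same change on two cores in this assay, a 1.3-fold higher number (0.12 log units; within the scatter) from compound 2 to compound 1 and a 2.0-fold higher number (0.29 log units; within the scatter) from compound 3 to compound 4, 1.5-fold (0.17 log units) apart, within the scatter of two such steps. Among the compounds shown here, this does not show that the two cores respond identically, since there is only one pair per core, the pairs also differ in where the group sits, and steps this small cannot separate a slight real difference from the scatter of the measurements.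

From the compounds shown here alone, all four compounds carry either iodo or nitro on this aromatic ring, so it remains open whether an amine or a carboxylic acid there would give a step beyond the scatter. Going by these compounds, whether the exchange would read the same way on a third core also remains open.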